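The source may hold more compounds than are shown below. What is called first, only, known or untested is meant among the compounds shown, and "the series" means these compounds.

Compound 1 `C[C@@H](c1ccc(NC(=O)N2CC(c3ccc(N)nc3)C2)cc1)N1Cc2ccccc2C1=O` gives 220000 nM in a physicochemical assay for solubility, read by LC-MS, in phosphate buffer, with a stated time of 24 h, at pH 6.8; a higher number here means a more soluble compound, a lower number a less soluble compound. Compound 2 `C[C@H](NC(=O)c1cccc(F)c1)c1ccc(NC(=O)N2CC(c3ccc(N)nc3)C2)cc1` gives 32000 nM in this assay. Compound 3 `C[C@@H](c1ccc(NC(=O)N2CC(c3cncc(N)c3)C2)cc1)N1Cc2ccccc2C1=O` gives 35000 nM in this assay.

The change in question is a group of 10 heavy atoms (7 carbon, 1 nitrogen, 1 oxygen, 1 fluorine; one six-membered aromatic ring of carbon only) in place of a group of 10 heavy atoms (8 carbon, 1 nitrogen, 1 oxygen; one five-membered non-aromatic ring with 1 hetero atom, one six-membered aromatic ring of carbon only), on a saturated chain carbon bound to an aromatic carbon and a saturated chain carbon, and it brought a 6.9-fold lower number from compound 1 to compound 2 (0.84 log units; beyond the scatter). Compound 4 `C[C@H](NC(=O)c1cccc(F)c1)c1ccc(NC(=O)N2CC(c3cncc(N)c3)C2)cc1` carries the same change, (a group of 10 heavy atoms (7 carbon, 1 nitrogen, 1 oxygen, 1 fluorine; one six-membered aromatic ring of carbon only) in place of a group of 10 heavy atoms (8 carbon, 1 nitrogen, 1 oxygen; one five-membered non-aromatic ring with 1 hetero atom, one six-membered aromatic ring of carbon only), on a saturated chain carbon bound to an aromatic carbon and a saturated chain carbon), at a place described in the same words, so it is the same change made on a different core. The two cores differ by 5-aminopyridin-3-yl in place of 6-aminopyridin-3-yl on a saturated ring carbon, a change that brought a 6.3-fold lower number from compound 1 to compound 3 (0.80 log units; beyond the scatter). Compound 2 and compound 3 sit within the scatter of each other.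

For compound 4 the step from compound 3 is expected to be a 5.0-fold lower number from compound 3 to compound 4 (0.70 log units; beyond the scatter), near the earlier one, because a 6.9-fold lower number from compound 1 to compound 2 (0.84 log units; beyond the scatter) was seen on the core of compound 1 and nothing here suggests the second core should answer differently. Compound 4 is therefore estimated at 7000 nM, likely between 2500 nM and 20000 nM.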

Compound 4, solubility: 17000 nM
Beside the measured number, compound 4's estimate is 2.4-fold (0.39 log units) below it; low and high end bracket the measured number.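

In this assay the ((3-fluorophenyl)carbonyl)amino group lowers the number on both cores, with a 6.9-fold lower number from compound 1 to compound 2 (0.84 log units; beyond the scatter) and a 2.1-fold lower number from compound 3 to compound 4 (0.31 log units; beyond the scatter), so the direction carries over, though the second step is smaller. With that group in place, the core difference gives a 1.9-fold lower number from compound 2 to compound 4 (0.27 log units; within the scatter), which lies within the scatter, unlike a 6.3-fold lower number from compound 1 to compound 3 (0.80 log units; beyond the scatter), so the two changes do not simply add up. One pair on each core cannot set a rule for the series, and nothing measured here explains the difference in size.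

Going by these compounds, it remains open whether a benzoylamino group without the fluorine would follow the same direction on both cores. The same question stands for a carboxylic acid at that saturated chain carbon.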